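Iodo on the Anilino Ring of Compound 2

The source may hold more compounds than are shown below. What is called first, only, known or untested is meant among the compounds shown, and "the series" means these compounds.

Measured compounds:
compound 1, `CCOC1=C(C(=O)c2ccccc2)C(c2ccc(Br)cc2)N(CCCn2ccnc2)C1=O`: 21900 nM
compound 2, `O=C(C1=C(Nc2ccccc2)C(=O)N(CCCn2ccnc2)C1c1ccc(Br)cc1)c1ccccc1`: 25700 nM

Both compounds were tested in a functional assay on U2OS cells (Homo sapiens) for antiproliferative activity, read by MTT assay, with a stated time of 72 h; on this read-out higher numbers stand for weaker inhibition and lower numbers for stronger inhibition. Within the data shown here, compound 2 carries the higher of the two numbers, yet the single step that links it to a neighbour, a 1.2-fold higher number from compound 1 to compound 2 (0.07 log units; within the scatter), lies within the scatter, so the two compounds are not distinguished by this read-out.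

Compound 3, `O=C(C1=C(Nc2ccc(I)cc2)C(=O)N(CCCn2ccnc2)C1c1ccc(Br)cc1)c1ccccc1`, is derived from compound 2 by one change: iodo in place of hydrogen on an aromatic carbon. Among the measured compounds shown here, the only measured step, the exchange of ethoxy for anilino on the double-bonded ring carbon, concerns a different part of the shared core and produced no shift beyond the scatter. For the measured compounds named here, no measured pair speaks to a substituent on the anilino ring itself, and no pair shows what a single halogen added to an aromatic ring does. Without such a precedent, the step from compound 2 to compound 3 is estimated as a 1.0-fold lower number from compound 2 to compound 3 (0.01 log units; within the scatter), that is, no change beyond the scatter, with a wide margin either way. Compound 3 is therefore expected to give about 25000 nM in this assay, within a range of 9000 nM to 70000 nM.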

Compound 3, half-maximal inhibitory concentration: 12000 nM
The estimate for compound 3 lay 2.1-fold (0.32 log units) above the measured number, within the range that was stated.
By their numbers in this assay, from the lowest: compounds 3, 1 and 2 (each within the scatter of the next, the first and the last beyond it).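

In this assay the anilino ring proves to be a place where a single added atom registers: phenyl to 4-iodophenyl gives a 2.1-fold lower number from compound 2 to compound 3 (0.33 log units; beyond the scatter), a modest step, but the only one among these three compounds that lies beyond the scatter. The exchange on the double-bonded ring carbon still does not separate the compounds, since a 1.8-fold lower number from compound 1 to compound 3 (0.26 log units; within the scatter) stands within the scatter just as a 1.2-fold higher number from compound 1 to compound 2 (0.07 log units; within the scatter) does, so ethoxy is not distinguished by this read-out from either anilino or (4-iodophenyl)amino. Nothing at hand offers an explanation for the step produced by iodo on the aromatic carbon.

The compounds shown leave open whether this step belongs to iodo itself or would also appear with fluoro, chloro, methoxy or a carboxylic acid on the same aromatic carbon. They also leave open whether the step would hold if a chloro or a hydrogen stood in place of the bromo on the other aromatic ring of the shared core.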